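Compound 3: cyclobutyl replaces 5-fluoropyridin-3-yl on oxygen

The source may report more compounds than this note shows. Statements on the series, on what has been measured and on what is new or still open speak of the compounds shown alone.

Compound 1 `Cc1ccc(Cn2c(=O)n(CC(C)(C)C(=O)O)c(=O)[nH]/c2=N\c2ccc(OC(C)C)c(Cl)c2)cc1`: 30.7%
Compound 2 `C[C@@H](Cn1c(=O)[nH]/c(=N\c2ccc(Oc3cncc(F)c3)cc2)n(Cc2ccc(Cl)cc2)c1=O)C(=O)O`: 74.3%

In an ADME assay on the whole organism (Rattus norvegicus) for pharmacokinetics, using cassette dosing, at a dose of 1 mg/kg by the oral route (on this read-out higher numbers stand for higher oral bioavailability and lower numbers for lower oral bioavailability), compound 2 stands highest of the two, and its lead over compound 1 lies beyond the scatter. Compound 3 `C[C@@H](Cn1c(=O)[nH]/c(=N\c2ccc(OC3CCC3)cc2)n(Cc2ccc(Cl)cc2)c1=O)C(=O)O` carries one change from compound 2: cyclobutyl in place of 5-fluoropyridin-3-yl on an oxygen on an aromatic ring. Among the measured compounds shown here, no measured pair shows this change alone. With compound 2 at 74.3% there is more room to fall than to rise, so a moderate fall is expected. The expected step is a number 14.3 percentage points lower from compound 2 to compound 3 (beyond the scatter) in size. Compound 3 is estimated in this assay at 60% (range 35% to 82%).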

Compound 3, oral bioavailability: 54.3%
Compound 3: the middle estimate sits 5.7 percentage points above what was measured; the measured number falls inside the stated range.
By their numbers in this assay, from the lowest: compound 1; then compound 3; then compound 2.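

In this assay, among the compounds shown here, this is the first pair to isolate the group on this oxygen, and replacing 5-fluoropyridin-3-yl with cyclobutyl gives a number 20 percentage points lower from compound 2 to compound 3 (beyond the scatter). The position therefore affects oral bioavailability, although compound 3 still reaches 54.3% with the non-aromatic ring of carbon only. No measurement shown gives a reason for the step. A single pair cannot separate the loss of the ring nitrogen, the fluorine or the aromatic ring. Nor does it show how a plain phenyl or a cyclopentyl on this oxygen would read.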